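The source may hold more compounds than are shown below. What is called first, only, known or untested is meant among the compounds shown, and "the series" means these compounds.

Working notes on the series.

Compound 1 `O=C(CCCCCCCn1cc(-c2cccnc2)nn1)Nc1ccccc1Cc1ccccc1` and compound 2 `O=C(CCCCCCCCn1cc(-c2cccnc2)nn1)Nc1ccccc1Cc1ccccc1` share a core that differs between them in a way not broken down here; compound 3 `O=C(CCCCCCCn1cc(-c2cccnc2)nn1)Nc1ccccc1Oc1ccccc1` and compound 4 `O=C(CCCCCCCCn1cc(-c2cccnc2)nn1)Nc1ccccc1Oc1ccccc1` are the corresponding pair carrying the other substituent. In a functional assay on SH-SY5Y cells (Homo sapiens) for cytotoxicity, tested at 300 nM (a lower number here means a stronger effect, a higher number a weaker effect of the compound at the concentration tested), compound 1 gives 75.2% and compound 2 gives 74.7%, two numbers within the scatter of each other. In this assay compound 3 gives 87.9%.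

The change from compound 1 to compound 3 is phenoxy in place of benzyl on an aromatic carbon and moves the read-out by a number 12.7 percentage points higher from compound 1 to compound 3 (beyond the scatter). The change from compound 2 to compound 4 is phenoxy in place of benzyl on an aromatic carbon, the same change at the same place. It occurs twice among these compounds, once measured, once not.

Among the compounds with values here, for compound 4 the step is expected to be about a number 12.3 percentage points higher from compound 2 to compound 4 (beyond the scatter), which rests on compound 3 and the step of a number 12.7 percentage points higher from compound 1 to compound 3 (beyond the scatter) as the only measured instance of this change. Compound 4 is therefore estimated at 87% in this assay, with a plausible range from 78% to 96%. With one prior instance only, this estimate carries the uncertainty of a single comparison.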

Compound 4, a percentage reported as activity, at one concentration (the size of the read-out at that concentration, not a potency): 79.5%
The estimate for compound 4 lay 7.5 percentage points above the measured number; measured number inside the range.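

In this assay, phenoxy in place of benzyl on the core of compound 2 gives a number 4.8 percentage points higher from compound 2 to compound 4 (within the scatter) and, set beside the step on the core of compound 1, the two steps cannot be told apart: the same change on two cores in this assay, a number 12.7 percentage points higher (beyond the scatter) from compound 1 to compound 3 and a number 4.8 percentage points higher (within the scatter) from compound 2 to compound 4, 7.9 percentage points apart, within the scatter of two such steps.
Both steps point the same way, so the two pairs give no sign that the shared change behaves differently on these two cores. They do not show that the change moves the read-out on the core of compound 2, where the step stays within the scatter, and two pairs say nothing about a size that would hold on any other core or about why the read-out moves.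

The compounds shown leave open how a phenylamino or benzoyl group would compare with benzyl and phenoxy in the same place. Also open, on these data alone, is whether the step would persist with a shorter or longer chain than those in these four compounds.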